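This account rests on a few compounds, and the source may have more. Where it says the series, first, only, none or still open, it means among the compounds named here.

Working notes on the series.

Going by the values given here, compound 3 `O=Cc1c(-c2ccc(Cl)cc2Cl)nc2sc(Cc3ccc(Cl)cc3)nn12` gives 79000 nM in an ADME assay on CCRF-CEM cells (Homo sapiens) for cytotoxicity, with a stated time of 72 h (a lower number here means a stronger inhibitor, a higher number a weaker inhibitor), the highest of the three numbers measured so far. Compound 1 `O=[N+]([O-])c1ccc(-c2nc3sc(Cc4ccc(Cl)cc4)nn3c2Br)cc1` gives 73000 nM in this assay, a value within the scatter of compound 3, so no order can be read between them. Among the compounds with values here, compound 2 `COc1ccc(-c2nc3sc(Cc4ccc(Cl)cc4)nn3c2C=O)cc1` gives 3800 nM in this assay, and the only measured step that touches the same position is a 21-fold higher number from compound 2 to compound 3 (1.32 log units; beyond the scatter), a large move.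

Compound 4 `O=Cc1c(-c2ccc([N+](=O)[O-])cc2)nc2sc(Cc3ccc(Cl)cc3)nn12` differs from compound 3 by 4-nitrophenyl in place of 2,4-dichlorophenyl on an aromatic carbon. The step from compound 2 to compound 3 shows that changing the group at this aromatic carbon can move the number a long way. Compound 1 also carries 4-nitrophenyl, but it differs from compound 4 in a second place as well, so its value only hints that a 4-nitrophenyl compound in this series may stay weak. Compound 4 is therefore expected to give a number somewhat lower than compound 3, but still well above compound 2, with the step estimated as a 2.6-fold lower number from compound 3 to compound 4 (0.42 log units; beyond the scatter). Compound 4 is estimated at 30000 nM in this assay, with a range from 8000 nM to 100000 nM.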

Compound 4, half-maximal inhibitory concentration: 13000 nM
Compound 4: the middle estimate sits 2.3-fold (0.36 log units) above what was measured; the range from low to high includes it.
By their numbers in this assay, from the lowest: compound 2; then compound 4; then compounds 1 and 3 (each within the scatter of the next).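

With the formyl group held, three aryl groups can now be ranked at this aromatic carbon in this assay: 4-nitrophenyl gives a 6.1-fold lower number from compound 3 to compound 4 (0.78 log units; beyond the scatter) and a 3.4-fold higher number from compound 2 to compound 4 (0.53 log units; beyond the scatter), which places it in the middle, with 4-methoxyphenyl at the low end and 2,4-dichlorophenyl at the high end. With 4-nitrophenyl held, the neighbouring ring atom also matters, since formyl in place of bromo gives a 5.6-fold lower number from compound 1 to compound 4 (0.75 log units; beyond the scatter), so the number depends on more than the aryl group alone. No measurement available here accounts for either change.

On these data alone, it remains open whether the same order of the three aryl groups holds with bromo in place of formyl. Also open, as far as these compounds go, is how an amine or a carboxylic acid would read on the ring atom that bears the formyl group.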